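Opening a Ring on the Amine Side Chain

The source may hold more compounds than are shown below. What is called first, only, known or untested is meant among the compounds shown, and "the series" means these compounds.

Measured so far:
Compound 1 `CC(C)=CCc1cc(C(=O)Nc2cc3ccc(OCC4CCCN(C)C4)c(C)c3oc2=O)ccc1O`: 1300 nM
Compound 2 `CC(C)=CCc1cc(C(=O)Nc2cc3ccc(OCC4CCN(C)C4)c(C)c3oc2=O)ccc1O`: 920 nM

In a functional assay on SK-BR-3 cells (Homo sapiens) for antiproliferative activity (a lower number here means a stronger inhibitor, a higher number a weaker inhibitor), compound 1 gives the highest of the two numbers, and its nearest neighbour is compound 2, which differs from it only by 1-methylpyrrolidin-3-yl in place of 1-methylpiperidin-3-yl. That step a 1.4-fold lower number from compound 1 to compound 2 (0.15 log units; within the scatter) stays within the scatter, so the two compounds cannot be told apart in this assay.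

Compound 3 `CC(C)=CCc1cc(C(=O)Nc2cc3ccc(OCCCN(C)C4CCCCC4)c(C)c3oc2=O)ccc1O` has not yet been measured. It differs from compound 1 as 2-(cyclohexyl(methyl)amino)ethyl in place of 1-methylpiperidin-3-yl on a saturated chain carbon bound to an oxygen on an aromatic ring. Among the compounds with values here, this is a larger change than the one from compound 1 to compound 2: the ring that carried the nitrogen is gone, and a carbon-only ring arrives on a longer chain. Within the data shown here, the only step that bears on it, the one from compound 1 to compound 2, was within the scatter, which gives no direction to lean on. The expected step of a 1.3-fold lower number from compound 1 to compound 3 (0.11 log units; within the scatter) is therefore small, with a wide range. For compound 3 the estimate is 1000 nM, between 300 nM and 3500 nM.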

Compound 3, half-maximal inhibitory concentration: 970 nM
Compound 3: the middle estimate sits 1.0-fold (0.01 log units) above what was measured, and the stated range covers the measured number.
By their numbers in this assay, from the lowest: compounds 2, 3 and 1 (each within the scatter of the next).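

In this assay, the nitrogen no longer has to sit inside a ring: with 3-(cyclohexyl(methyl)amino)propoxy in place of (1-methylpiperidin-3-yl)methoxy, the result is a 1.3-fold lower number from compound 1 to compound 3 (0.13 log units; within the scatter), and the comparison with the pyrrolidine compound gives a 1.1-fold higher number from compound 2 to compound 3 (0.02 log units; within the scatter). Within the data shown here, the earlier pair showed only that one ring size could replace another, whereas these steps show that a much larger change in the shape of the side chain also leaves the number within the scatter. Nothing available explains why these three side chains cannot be told apart.

Going by these compounds, all three compounds keep a nitrogen bearing a methyl group, so the role of that amine remains open. A cyclohexylpropyl chain with no nitrogen, or a chain ending in a carboxylic acid, would test whether this position responds to any change at all.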